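The source may report more compounds than this note shows. Statements on the series, on what has been measured and on what is new or still open speak of the compounds shown alone.

Measured compounds:
compound 1, `Nc1ncnc2c1ncn2/C=C/C=O` — > 100000 nM
compound 2, `O=C/C=C/n1cc(F)c(=O)[nH]c1=O` — 90000 nM

Both compounds were tested in a functional assay on HeLa cells (Homo sapiens) for inhibition; a higher number here means a weaker inhibitor, a lower number a stronger inhibitor. In this assay compound 1 gives only a limit, > 100000 nM, and not a number. Compound 2 gives 90000 nM in this assay. Where compound 1 stands is therefore set by the limit of > 100000 nM in this assay, at which 1 of the 2 values shown sits, and no step between the two measured compounds is known, so their values can only be stated side by side.

Compound 3, `CCOC(=O)/C=C/n1cnc2c(N)ncnc21`, has not yet been measured. It differs from compound 1 in one place: ethoxy in place of hydrogen on a carbonyl carbon. Among the compounds with values here, with no measured step to lean on, the size of this change can only be expected. The author expects no movement beyond the usual scatter of this assay, and if anything a drift toward weaker inhibition, and estimates the step as a step that the limit leaves unreadable from compound 1 to compound 3. Compound 3 is accordingly expected to come out at 150000 nM, somewhere between 30000 nM and 1000000 nM, with a good chance that this assay once more reports only a limit rather than a number.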

Compound 3, half-maximal inhibitory concentration: 100000 nM
Compound 3: middle estimate off by 1.5-fold (0.18 log units), on the high side, and the stated range covers the measured number.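

In this assay compound 3 gives an actual number at this position, 100000 nM, so the ethoxycarbonyl compound can be placed on the scale of the assay. Compound 1, which carries the formyl group here, gives only a limit, > 100000 nM. Ethoxy in place of hydrogen on a carbonyl carbon therefore gives a number no higher from compound 1 to compound 3 (the limit leaves the size open), and the size of this step cannot be read because one end of it is a limit: the limit of > 100000 nM in this assay, at which 1 of the 3 values shown sits.

The compounds shown leave open how a carboxylic acid, an amide or a longer alkoxy chain on the same carbonyl carbon would read in this assay. As far as these compounds go, it also remains open whether ethoxy in place of hydrogen would read the same way on the core of compound 2, which gives 90000 nM.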